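Swapping Methoxy for Methyl at the Aniline of Compound 1

This account rests on a few compounds, and the source may have more. Where it says the series, first, only, none or still open, it means among the compounds named here.

Three compounds have been measured in a functional assay on NCI-H226 cells (Homo sapiens) for inhibition, read by MTT assay, with a stated time of 48 h, tested at 10 uM; a higher number here means more inhibition at the concentration tested (going by the name of the read-out), a lower number less inhibition:
compound 1, `COc1cc(NC(=O)Nc2cc(Nc3ccc(OC)c(C)c3)ncn2)cc(OC)c1`, gives 39.7%;
compound 2, `CC(C)(C)c1ccc(Nc2cc(NC(=O)Nc3c(Cl)cccc3Cl)ncn2)cc1`, gives 40%;
compound 3, `Cc1cc(F)cc(Nc2cc(NC(=O)Nc3c(Cl)cccc3Cl)ncn2)c1`, gives 78.1%.

Among these three numbers, compound 1 stands lowest. Its nearest neighbour is compound 2, whose value lies within the usual scatter of compound 1, so no order can be read between them. Within the data shown here, compound 3 lies furthest away, with a value beyond the scatter above compound 1; since compounds 2 and 3 share a different urea part from compound 1, their two values show only that this pair of structures reaches different levels, and nothing about the change considered here.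

The compound not yet measured is compound 4, `COc1cc(NC(=O)Nc2cc(Nc3ccc(C)c(C)c3)ncn2)cc(OC)c1`. It differs from compound 1 in one place: methyl in place of methoxy on an aromatic carbon. Among the measured compounds shown here, nothing measured so far isolates this change. For the measured compounds named here, no pair of measured compounds differs in that way alone. With one acceptor removed and one heavy atom less at that position, the step from compound 1 to compound 4 in this assay is expected to be small, a number 5.3 percentage points higher from compound 1 to compound 4 (within the scatter), likely not beyond the scatter, and if anything slightly upward. Compound 4 is therefore estimated to give 45%, within a range from 25% to 65%.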

Compound 4, a percentage reported as inhibition, at one concentration (the size of the read-out at that concentration, not a potency): 45.3%
Beside the measured number, compound 4's estimate is 0.3 percentage points below it; the measured number falls inside the stated range.
By their numbers in this assay, from the lowest: compounds 1, 2 and 4 (each within the scatter of the next); then compound 3.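

Among these compounds, this is the first direct reading of this change: in this assay, replacing the 4-methoxy-3-methylphenyl group with the 3,4-dimethylphenyl group gives a step of a number 5.6 percentage points higher from compound 1 to compound 4 (within the scatter). On the core of compound 1, methyl in place of methoxy on this aromatic carbon, ortho to a methyl group and para to a large group, therefore gives no difference that can be told from the usual scatter, even though the hydrogen-bond acceptor of the methoxy group is gone. Nothing available explains why the two groups cannot be told apart in this assay.

The compounds shown leave open how this position responds to groups other than methoxy and methyl, such as a hydroxyl, an ethyl or a dimethylamino group, any of which could show whether the assay reading moves at this place at all. They also leave open whether the same exchange would read alike on the different urea part carried by compound 2 and compound 3, as this one step comes from the urea part of compound 1 alone.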